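The compounds below may be only part of what the source reports. "The series", "measured", "known", "first", "only" and "open" are said of these compounds alone.

Measured in a functional assay on PC-3 cells (Homo sapiens) for cytotoxicity, read by MTT assay, with a stated time of 72 h; a higher number here means a weaker inhibitor, a lower number a stronger inhibitor:
- Compound 1 `O=C(/C=C/c1ccc([N+](=O)[O-])cc1)Nc1cc2c(Nc3ccc(F)c(Cl)c3)ncnc2cc1O[C@H]1CCOC1`: 22800 nM
- Compound 2 `N#Cc1ccc(/C=C/C(=O)Nc2cc3c(Nc4ccc(F)c(Cl)c4)ncnc3cc2O[C@H]2CCOC2)cc1`: 36600 nM

For the measured compounds named here, compound 2 has only one measured neighbour, and their values cannot be told apart. The measured step is a 1.6-fold higher number from compound 1 to compound 2 (0.21 log units; within the scatter). Compound 3 `O=C(/C=C/c1cc(Br)c(O)c(Br)c1)Nc1cc2c(Nc3ccc(F)c(Cl)c3)ncnc2cc1O[C@H]1CCOC1` carries 3,5-dibromo-4-hydroxyphenyl in place of 4-cyanophenyl on a double-bonded chain carbon bound to a double-bonded chain carbon. Going by the values given here, no measured step covers this exchange. Among the compounds with values here, the only guide is the step to compound 2 from compound 1, a different swap, which stayed small in this assay. No shift beyond the scatter is therefore expected, and the expected step is a 1.5-fold lower number from compound 2 to compound 3 (0.17 log units; within the scatter). The estimate for compound 3 is 25000 nM, with an expected range from 8000 nM to 70000 nM.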

Compound 3, half-maximal inhibitory concentration: 25500 nM
Compound 3: middle estimate off by 1.0-fold (0.01 log units), on the low side, within the range that was stated.
By their numbers in this assay, from the lowest: compounds 1, 3 and 2 (each within the scatter of the next).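

In this assay, for the compounds shown here, 3,5-dibromo-4-hydroxyphenyl, which brings a hydrogen-bond donor that 4-cyanophenyl lacks, still gives no step that can be told from the scatter: a 1.4-fold lower number from compound 2 to compound 3 (0.16 log units; within the scatter), and a 1.1-fold higher number from compound 1 to compound 3 (0.05 log units; within the scatter). At this place on the chain, all three substituted phenyl rings shown therefore give values that cannot be told apart. Nothing available accounts for this. From the compounds shown here alone, whether any group here can move the number beyond the scatter stays open, and so does the outcome with an amine or a carboxylic acid in place of the ring.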